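The compounds below may be only part of what the source reports. "The series", "measured", "known", "first", "only" and "open" are said of these compounds alone.

In a functional assay on T47D cells (Homo sapiens) for cytotoxicity, read by CCK-8 assay (a lower number here means a stronger inhibitor, a higher number a weaker inhibitor), three compounds sharing one core have been measured. Compound 1 `Oc1cccc(-c2cc(-c3cccs3)cc(-c3cccc(O)c3)n2)c1` gives 770 nM, compound 2 `Oc1cccc(-c2cc(-c3ccsc3)cc(-c3cccc(O)c3)n2)c1` gives 1510 nM, and compound 3 `Oc1cccc(-c2cc(-c3ccco3)cc(-c3ccccc3O)n2)c1` gives 820 nM. Within the data shown here, the only step between two measured compounds that differ in one place is a 2.0-fold higher number from compound 1 to compound 2 (0.29 log units; within the scatter), and that swap of one thiophene attachment for another stays within the usual scatter. Compound 3 sits within the scatter of both of its neighbours: its number is within the scatter of compound 1 and also within the scatter of compound 2, so none of the three can be told apart with confidence.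

Compound 4 `Oc1cccc(-c2cc(-c3ccco3)cc(-c3cccc(O)c3)n2)c1` has not yet been measured. It differs from compound 3 by 3-hydroxyphenyl in place of 2-hydroxyphenyl on an aromatic carbon; the two have the same atoms, joined differently, and the change sits next to the ring nitrogen of the shared core. Among the measured compounds shown here, no measured pair shows this particular move of the hydroxyl group, and the one measured step concerns a different part of the molecule, so nothing in the data points to a change beyond the scatter in this assay. The expected step is a 1.0-fold lower number from compound 3 to compound 4 (0.01 log units; within the scatter). Compound 4 is therefore estimated at 800 nM, with a range from 400 nM to 1600 nM.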

Compound 4, half-maximal inhibitory concentration: 3520 nM
Compound 4: middle estimate off by 4.4-fold (0.64 log units), on the low side; the whole stated range lies below it.
By their numbers in this assay, from the lowest: compounds 1, 3 and 2 (each within the scatter of the next); then compound 4.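

In this assay, among these compounds, the hydroxyl's location on the aryl group next to the ring nitrogen of the shared core proves to matter: 3-hydroxyphenyl in place of 2-hydroxyphenyl gives a 4.3-fold higher number from compound 3 to compound 4 (0.63 log units; beyond the scatter) and is the first change here beyond the scatter, even though the two groups have the same atoms and the same hydrogen-bond donor and acceptor counts. The ring at the other position also proves to matter, which the thiophene pair alone did not show: with the 3-hydroxyphenyl groups kept, furan-2-yl in place of thiophen-2-yl gives a 4.6-fold higher number from compound 1 to compound 4 (0.66 log units; beyond the scatter) and furan-2-yl in place of thiophen-3-yl gives a 2.3-fold higher number from compound 2 to compound 4 (0.37 log units; beyond the scatter), while a 2.0-fold higher number from compound 1 to compound 2 (0.29 log units; within the scatter) stays within the scatter. No accompanying measurement explains why either change raises the number.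

Going by these compounds, it remains open whether 2-hydroxyphenyl would give a similar step alongside a thiophen-2-yl or thiophen-3-yl group, as it appears here only with furan-2-yl. Also open, on these data alone, is what would happen with an amine or a methoxy group in place of the hydroxyl, or with an unsubstituted phenyl ring.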